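The source may report more compounds than this note shows. Statements on the series, on what has been measured and on what is new or still open speak of the compounds shown alone.

Series notes. In a functional assay on A549 cells (Homo sapiens) for inhibition, read by ELISA, with a stated time of 24 h (a higher number here means a weaker inhibitor of growth, a lower number a stronger inhibitor of growth), compound 1 `O=C(/C=C/c1ccccc1OC(=O)c1ccccc1)NOC(=O)N1CCOCC1` gives 25200 nM. Compound 2 `CO/N=C/C=C/c1ccccc1OC(=O)c1ccccc1` reaches only a limit in this assay, > 100000 nM; that limit is the limit of > 100000 nM in this assay, at which 1 of the 2 values shown sits. Compound 3 `CC(=O)ONC(=O)/C=C/c1ccccc1OC(=O)c1ccccc1` has not yet been measured in this assay. The change from compound 2 to compound 3 is a group of 7 heavy atoms (3 carbon, 1 nitrogen, 3 oxygen; no ring) in place of a group of 4 heavy atoms (2 carbon, 1 nitrogen, 1 oxygen; no ring), on a double-bonded chain carbon bound to a double-bonded chain carbon. For the measured compounds named here, no measured pair isolates this change. The acetoxycarbamoyl that enters brings compound 3 nearer to compound 1, which in this assay gives 25200 nM. Compound 3 is therefore expected to come off the limit, with a step of an at least 5.0-fold lower number from compound 2 to compound 3 (0.69 log units; beyond the scatter) toward stronger inhibition, beyond the usual scatter. The estimate for compound 3 is 20000 nM, between 5000 nM and 100000 nM.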

Compound 3, concentration for 50% growth inhibition: 30200 nM
Beside the measured number, compound 3's estimate is 1.5-fold (0.18 log units) below it, and the stated range covers the measured number.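

In this assay, acetoxycarbamoyl on a double-bonded chain carbon bound to a double-bonded chain carbon gives an at least 3.3-fold lower number from compound 2 to compound 3 (0.51 log units; beyond the scatter), so this position responds to the change. Compound 2 stands at a limit, so that step is a bound and not a size: the limit of > 100000 nM in this assay, at which 1 of the 3 values shown sits. Methyl in place of morpholin-4-yl on a carbonyl carbon gives a 1.2-fold higher number from compound 1 to compound 3 (0.08 log units; within the scatter), so these two groups do not separate here.

Open, going by these compounds, is which part of the acetoxycarbamoyl carries the step, and whether an amine or a longer chain on that carbonyl carbon would move the number beyond the scatter.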